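This account rests on a few compounds, and the source may have more. Where it says the series, first, only, none or still open, it means among the compounds named here.

Measured compounds:
compound 1 `CCCCCC[C@@H](O)[C@H](OS(=O)(=O)[O-])[C@H](O)C[S@+]1C[C@@H](O)[C@H](O)[C@H]1CO`: 1700 nM
compound 2 `CCC[C@@H](O)[C@H](O)[C@H](O)C[S@+]1C[C@@H](O)[C@H](O)[C@H]1CO`: 5000 nM

In an assay on intestine for inhibition of Maltase-glucoamylase (Homo sapiens) (a higher number here means a weaker inhibitor, a lower number a stronger inhibitor), compound 2 gives 5000 nM, the highest of the two numbers shown; compound 1 sits at a lower number in this assay, beyond the scatter, but the two compounds differ in more than one place, so no single step is known. Compound 3 `CCC[C@@H](O)[C@H](OS(=O)(=O)[O-])[C@H](O)C[S@+]1C[C@@H](O)[C@H](O)[C@H]1CO` carries a group of 4 heavy atoms (3 oxygen, 1 sulfur; no ring) in place of a hydrogen atom, on an oxygen on a saturated carbon. For the measured compounds named here, with no step for this change alone, the expectation rests on what compound 1 and compound 2 show. Compound 3 is therefore expected to give a modestly lower number, a 2.0-fold lower number from compound 2 to compound 3 (0.30 log units; within the scatter). The estimate for compound 3 is 2500 nM, with a range from 800 nM to 8000 nM.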

Compound 3, half-maximal inhibitory concentration: 4800 nM
For compound 3 the middle estimate is 1.9-fold (0.28 log units) below the measured one, and the stated range covers the measured number.
By their numbers in this assay, from the lowest: compound 1; then compounds 3 and 2 (each within the scatter of the next).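

In this assay, the group of 4 heavy atoms (3 oxygen, 1 sulfur; no ring) in place of a hydrogen atom on this oxygen on a saturated carbon has no effect beyond the scatter on the short chain (a 1.0-fold lower number from compound 2 to compound 3 (0.02 log units; within the scatter)). With that group kept, hydrogen in place of propyl on a saturated chain carbon does leave a step beyond the scatter (a 2.8-fold higher number from compound 1 to compound 3 (0.45 log units; beyond the scatter)). Nothing available accounts for either result.

On these data alone, whether the group is equally silent on the longer chain of compound 1 stays open. So does how a carboxylic acid on this oxygen, or a still longer chain, would read in this assay.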